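Methyl in Place of Phenyl: Maximal Response Expected Unchanged

The source may hold more compounds than are shown below. What is called first, only, known or untested is meant among the compounds shown, and "the series" means these compounds.

Compound 1 `CN1CCN(c2ccc3c(c2)c(S(=O)(=O)c2cccc4ccccc24)nn3Cc2ccccc2)CC1`: 100%
Compound 2 `CN1CCN(c2ccc3[nH]nc(S(=O)(=O)c4ccccc4Cl)c3c2)CC1`: 100%

In a functional assay on HeLa cells for antagonist activity at 5-hydroxytryptamine receptor 6 (Homo sapiens) (a higher number here means a larger maximal response, a lower number a smaller maximal response), compound 1 gives 100% and compound 2 gives 100%, so compound 1 stands level with compound 2 at the digits shown, within the scatter. Compound 3 `CCn1nc(S(=O)(=O)c2cccc3ccccc23)c2cc(N3CCN(C)CC3)ccc21` has not been measured. It differs from compound 1 by methyl in place of phenyl on a saturated chain carbon bound to an aromatic nitrogen. Among the measured compounds shown here, no measured pair shows this change, so its step size in this assay is not known from the data. Because compound 1 gives 100% and compound 2 gives 100%, both full responses, no step beyond the scatter is expected. Compound 3 is estimated at 100%, range 85% to 105%. The expected step is no change at the digits printed from compound 1 to compound 3 (within the scatter).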

Compound 3, largest response reached (reported as Imax), in percent of the reference or control that the assay uses: 100%
Compound 3: the middle estimate sits on the measured number at the digits printed; the measured number falls inside the stated range.
By their numbers in this assay, from the lowest: compounds 1, 2 and 3 (each within the scatter of the next).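

In this assay, among the compounds shown here, the first measured pair for methyl in place of phenyl on a saturated chain carbon bound to an aromatic nitrogen, also read as benzyl to ethyl, gives this step: no change at the digits printed from compound 1 to compound 3 (within the scatter). At this position, then, the maximal response of compound 1 is kept when the phenyl ring is lost. Nothing available accounts for this result. The compounds shown leave open whether an amine, a carboxylic acid or a longer chain on this carbon would keep that response.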